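Swapping a Hydroxy for a Methoxy in an Acrylamide Series

The compounds below may be only part of what the source reports. "The series", "measured", "known", "first", "only" and "open" are said of these compounds alone.

Measured compounds:
compound 1 `CCCCC(OC)c1cccc(NC(=O)NCCCCl)c1`: 51000 nM
compound 2 `CCCCC(OC)c1cccc(NC(=O)NC(=O)CCl)c1`: 4200 nM
compound 3 `C=CC(=O)Nc1cccc(C(O)CCCC)c1`: 98000 nM

In a functional assay on M21 cells (Homo sapiens) for antiproliferative activity, with a stated time of 48 h (a lower number here means a stronger inhibitor, a higher number a weaker inhibitor), compound 3 gives 98000 nM, the highest of the three numbers. Its nearest neighbour is compound 1, whose value in this assay of 51000 nM lies within the scatter of compound 3, so the two cannot be ordered. Compound 2, which in this assay gives 4200 nM, sits far beyond that scatter and is the strongest inhibitor of the three.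

Compound 4 `C=CC(=O)Nc1cccc(C(CCCC)OC)c1` differs from compound 3 by methyl in place of hydrogen on an oxygen on a saturated carbon. Among the compounds with values here, the one measured step, a 12-fold lower number from compound 1 to compound 2 (1.08 log units; beyond the scatter), concerns a different part of the molecule and offers no guide here. Compounds 1 and 2 both carry the methoxy while compound 3 carries the hydroxy, but they differ elsewhere as well, so their numbers do not isolate this change. I therefore expect a step of a 1.2-fold lower number from compound 3 to compound 4 (0.09 log units; within the scatter), nothing beyond the scatter. Compound 4 is expected to give about 80000 nM in this assay, with a range from 30000 nM to 250000 nM.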

Compound 4, half-maximal inhibitory concentration: 48000 nM
For compound 4 the middle estimate is 1.7-fold (0.22 log units) above the measured one, within the range that was stated.
By their numbers in this assay, from the lowest: compound 2; then compounds 4, 1 and 3 (each within the scatter of the next, the first and the last beyond it).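

In this assay, putting methyl in place of hydrogen on this oxygen, turning hydroxy into methoxy, gives a 2.0-fold lower number from compound 3 to compound 4 (0.31 log units; beyond the scatter); this first direct reading of the change shows that the hydroxy hydrogen is not needed for the activity seen here. With the methoxy kept, changing the group on the carbonyl carbon can matter more: vinyl in place of ((chloromethyl)carbonyl)amino gives an 11-fold higher number from compound 2 to compound 4 (1.06 log units; beyond the scatter), although vinyl in place of (3-chloropropyl)amino goes against any general trend, with a 1.1-fold lower number from compound 1 to compound 4 (0.03 log units; within the scatter). No measurement available here explains why the methyl shifts the number.

As far as these compounds go, whether a larger group on this oxygen, such as ethyl or benzyl, would move the number further remains open. So does whether an amine in place of the hydroxy would behave like the methoxy, and whether the same methyl step would hold with the (chloromethyl)carbonyl end.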